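Tolerance of a Branched Hydroxy Chain on HEp-2 Cells

The compounds below may be only part of what the source reports. "The series", "measured", "known", "first", "only" and "open" are said of these compounds alone.

Compound 3 `CS(=O)(=O)c1nn(Cc2nc3cc(Cl)ccc3n2CCCCO)c2cnccc12` stands at a limit in an ADME assay on HEp-2 cells (Homo sapiens) for cytotoxicity, with a stated time of 4 days; a lower number here means that less compound is tolerated, a higher number that more compound is tolerated: compound 3 gives > 100000 nM, which is a limit of the measurement rather than a number. Compound 1 `CS(=O)(=O)CCCn1c(Cn2nc(S(C)(=O)=O)c3ccncc32)nc2cc(Cl)ccc21` gives > 100000 nM, also a limit. Compound 2 `CS(=O)(=O)c1nn(Cc2nc3cc(Cl)ccc3n2CCO)c2cnccc12` gives > 100000 nM, again a limit. Because the limit of > 100000 nM in this assay, at which 3 of the 3 values shown sit, holds all three, the steps a step that the two limits leave unreadable from compound 1 to compound 2, a step that the two limits leave unreadable from compound 1 to compound 3 and a step that the two limits leave unreadable from compound 2 to compound 3 cannot be sized at all. Compound 4 `CC(C)(CO)Cn1c(Cn2nc(S(C)(=O)=O)c3ccncc32)nc2cc(Cl)ccc21` differs from compound 3 by 1-(hydroxymethyl)-1-methylethyl in place of 3-hydroxypropyl on a saturated chain carbon bound to an aromatic nitrogen. The measured steps thus give neither a direction nor a size for this assay, so the expected step of a number no higher from compound 3 to compound 4 (the limit leaves the size open) is none beyond the scatter, and compound 4 will most likely again be reported as a limit. Compound 4 is estimated at 100000 nM, with a range from 50000 nM to 200000 nM.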

Compound 4, half-maximal cytotoxic concentration: > 100000 nM
Compound 4: no number, only a limit (the forecaster's own chance of this, stated with the estimate: 85%); the middle value sits exactly at the limit.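

No step from compound 1, compound 2 or compound 3 to compound 4 can be read, because all four compounds give the same limit rather than a number: the limit of > 100000 nM in this assay, at which 4 of the 4 values shown sit.

The compounds shown leave open whether any of these chains on the shared core differs from another in this assay.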